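A few compounds are considered here, and "the series" means these few. Any claim that something is new, unique, unknown or untested is made for them only; others in the source may bear on it.

Measured in a functional assay on RS4-11 cells (Homo sapiens) for inhibition, read by CCK-8 assay, with a stated time of 48 h, tested at 20 uM; on this read-out lower numbers stand for less inhibition of growth and higher numbers for more inhibition of growth at the one concentration tested:
- Compound 1 `Cc1ccc(S(=O)(=O)Oc2ccccc2/C=C(\C#N)C(=O)Nc2nnc(C)s2)cc1`: 33%
- Compound 2 `Cc1ccc(S(=O)(=O)Oc2cccc(/C=C(\C#N)C(=O)Nc3nnc(C)s3)c2)cc1`: 28%
- Compound 3 `COc1ccc(Cc2nnc(NC(=O)/C(C#N)=C/c3ccccc3OS(=O)(=O)c3ccc(C)cc3)s2)cc1`: 70%

Among these three, compound 3 stands highest at 70%, clearly beyond the scatter of both others. Compound 1 and compound 2 lie within the scatter of each other.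

Compound 4 `COc1ccc(Cc2nnc(NC(=O)/C(C#N)=C/c3ccccc3OS(=O)(=O)c3ccccc3[N+](=O)[O-])s2)cc1` keeps the rest of compound 3 and changes one group, with 2-nitrophenyl in place of 4-methylphenyl on a sulfonyl sulfur. Among the measured compounds shown here, the only measured step between compounds that differ in one place is a number 37 percentage points higher from compound 1 to compound 3 (beyond the scatter). That large step came from 4-methoxyphenyl in place of hydrogen on a saturated chain carbon bound to an aromatic carbon, which is a different place in the structure. It shows that this assay can respond strongly to a single change, but it gives no size or direction for this one. For the measured compounds named here, no measured pair varies the group on the sulfonyl sulfur, so the expectation is only weakly grounded. With no evidence for a shift, no step beyond the scatter is expected, and the wide range allows for a surprise either way. The expected change is a number 5 percentage points lower from compound 3 to compound 4 (within the scatter). For compound 4 the estimated value is 65%, with an expected range from 43% to 85%.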

Compound 4, percent growth inhibition at one concentration: 68%
For compound 4 the middle estimate is 3 percentage points below the measured one; low and high end bracket the measured number.
By their numbers in this assay, from the lowest: compounds 2 and 1 (each within the scatter of the next); then compounds 4 and 3 (each within the scatter of the next).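

In this assay, among the compounds shown here, the replacement of 4-methylphenyl by 2-nitrophenyl on the sulfonyl sulfur gives a number 2 percentage points lower from compound 3 to compound 4 (within the scatter) and so stays within the usual scatter, which makes this the first measured pair to vary this position. On paper the exchange is not a small one, since the entering group has more heavy atoms and brings hydrogen-bond acceptors and a double bond outside the ring, yet this read-out does not separate the two compounds, whereas the change elsewhere in the structure gave a number 37 percentage points higher from compound 1 to compound 3 (beyond the scatter) as a large step. Nothing measured here accounts for the lack of a shift at the sulfonyl sulfur.

As far as these compounds go, both aromatic groups at this position carry a single substituent on a six-membered carbon ring, so it remains open whether a plain methyl on the sulfonyl sulfur, or a phenyl bearing an amine or a carboxylic acid, would also leave the number in place. From the compounds shown here alone, it also remains open whether 2-nitrophenyl would behave the same way on compound 1, which lacks the 4-methoxyphenyl group, and whether a reading at other concentrations would still show no separation between compound 3 and compound 4.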